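Nitro in place of bromo on aryl triazenes: cytotoxicity

The compounds below may be only part of what the source reports. "The series", "measured", "known", "first", "only" and "open" are said of these compounds alone.

Compound 1 `O=[N+]([O-])c1ccc(/N=N/N2CCCC2)cc1` in an ADME assay on MDBK cells (Bos taurus) for cytotoxicity, read by MTT assay, with a stated time of 96 h (a lower number here means that less compound is tolerated, a higher number that more compound is tolerated), is reported only as a limit of the assay, > 100000 nM.
Compound 2 `Brc1cccc(/N=N/N2CCCCC2)c1` in this assay is likewise reported as a limit, > 100000 nM.
Compound 3 `Brc1ccc(/N=N/N2CCCC2)cc1` in this assay is also reported as a limit, > 100000 nM.

All three values therefore share (the limit of > 100000 nM in this assay, at which 3 of the 3 values shown sit). Among the measured compounds shown here, the one step that can be paired, a step that the two limits leave unreadable from compound 3 to compound 1, is the change (nitro in place of bromo on an aromatic carbon); its size cannot be read because of the limit of > 100000 nM in this assay, at which 3 of the 3 values shown sit. The cores of compound 2 and compound 3 differ in a way that is not broken down here.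

Compound 4 `O=[N+]([O-])c1cccc(/N=N/N2CCCCC2)c1` has not yet been measured in this assay. It arises from compound 2 by nitro in place of bromo on an aromatic carbon, the same kind of change as from compound 3 to compound 1, though the place differs: meta to a group of 8 heavy atoms rather than para to a group of 7 heavy atoms.

The step that the limit leaves unreadable from compound 2 to compound 4 is expected to be small, because compound 2 already sits at > 100000 nM and the matching step that the two limits leave unreadable from compound 3 to compound 1 showed no readable loss of tolerance. Compound 4 is thus estimated at 150000 nM, within 60000 nM to 400000 nM, most likely reported again only as a limit.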

Compound 4, half-maximal cytotoxic concentration: > 100000 nM
Compound 4 gave a limit, no number; the forecaster's own chance of this, stated with the estimate: 85%; the middle value lies beyond the limit too.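

Among the compounds shown here, compound 2 and compound 4 add no new readable step in this assay, because both are reported only as limits of the assay and not as numbers: the limit of > 100000 nM in this assay, at which 4 of the 4 values shown sit.

The compounds shown leave open whether any of them has a measurable cytotoxic concentration in this assay and how far nitro in place of bromo on an aromatic carbon shifts it.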